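The source may report more compounds than this note shows. Statements on the series, on what has been measured and on what is new or still open speak of the compounds shown alone.

In this assay, a functional assay on DWD cells (Homo sapiens) for inhibition, read by sulforhodamine B assay (on this read-out lower numbers stand for stronger inhibition of growth and higher numbers for weaker inhibition of growth), compound 1 `Oc1cccc2[nH]c(-c3ccc(-c4ccc(-c5ccc(OC(F)(F)F)cc5)cc4)cc3)nc12` gives 3100 nM. Compound 2 `Oc1ccc(-c2ccc(-c3ccc(-c4nc5c(O)cccc5[nH]4)cc3)cc2)cc1` gives 2700 nM. Compound 3 `Cc1ccc2[nH]c(-c3ccc(-c4ccc(-c5ccc(OC(F)(F)F)cc5)cc4)cc3)nc2c1` gives 41100 nM.

Compound 3 differs from compound 1 in its core: 5-methyl-1H-benzimidazol-2-yl in place of 4-hydroxy-1H-benzimidazol-2-yl on an aromatic carbon. That change made a step of a 13-fold higher number from compound 1 to compound 3 (1.12 log units; beyond the scatter). Compound 2 differs from compound 1 at the far end of the chain of rings: hydrogen in place of trifluoromethyl on an oxygen on an aromatic ring. That step was a 1.1-fold lower number from compound 1 to compound 2 (0.06 log units; within the scatter), so the two values show no real difference.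

Compound 4 `Cc1ccc2[nH]c(-c3ccc(-c4ccc(-c5ccc(O)cc5)cc4)cc3)nc2c1` is not yet measured. It carries the core of compound 3 and differs from it by hydrogen in place of trifluoromethyl on an oxygen on an aromatic ring, the same change as from compound 1 to compound 2, at a place described in the same words. On that basis the expected step is a 1.1-fold lower number from compound 3 to compound 4 (0.05 log units; within the scatter), resting on the earlier step of a 1.1-fold lower number from compound 1 to compound 2 (0.06 log units; within the scatter). Compound 4 is therefore estimated at 37000 nM, between 15000 nM and 90000 nM.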

Compound 4, concentration for 50% growth inhibition: 21200 nM
The estimate for compound 4 lay 1.7-fold (0.24 log units) above the measured number; low and high end bracket the measured number.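

In this assay, replacing trifluoromethoxy with hydroxy on the core of compound 3 gave a 1.9-fold lower number from compound 3 to compound 4 (0.29 log units; within the scatter), so this pair, like the first, shows no real difference. Set side by side, the change behaves alike on the two cores: the same change on two cores in this assay, a 1.1-fold lower number (0.06 log units; within the scatter) from compound 1 to compound 2 and a 1.9-fold lower number (0.29 log units; within the scatter) from compound 3 to compound 4, 1.7-fold (0.23 log units) apart, within the scatter of two such steps. This shows that in these two pairs the swap left the number within the scatter on both cores, but two pairs do not show that it would do so on any other core, and they do not explain why.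

Still open, as far as these compounds go, is whether an amine or a carboxylic acid in place of trifluoromethoxy on the aromatic ring would also leave the number unchanged.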